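Sulfonyl aryl swap in a series without a readable step

The compounds below may be only part of what the source reports. "The series", "measured", "known", "first", "only" and "open" are said of these compounds alone.

Compound 3 `COc1ccc(-c2cc(=O)c3c(OC)cc(OC)cc3n2S(=O)(=O)c2ccc(C=O)cc2)cc1` is measured in an ADME assay on BJ cells (Homo sapiens) for antiproliferative activity, with a stated time of 72 h (a higher number here means that more compound is needed for the effect, a lower number that less compound is needed), and gives only a limit of the assay, > 34400 nM. Compound 1 `COc1ccc(-c2cc(=O)c3c(OC)cc(OC)cc3n2Cc2ccccc2)cc1` also sits at a limit in this assay, namely > 34400 nM. Compound 2 `C=CCNC(=O)n1c(-c2ccc(OC)cc2)cc(=O)c2c(OC)cc(OC)cc21` gives 74000 nM in this assay. The three steps among them, a step that the limit leaves unreadable from compound 1 to compound 2, a step that the two limits leave unreadable from compound 1 to compound 3 and a step that the limit leaves unreadable from compound 2 to compound 3, cannot be sized because of the limit of > 34400 nM in this assay, at which 2 of the 3 values shown sit. For the measured compounds named here, compound 3 thus stands at the limit together with compound 1, and compound 2 is the only number in the set.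

Compound 4 `COc1ccc(-c2cc(=O)c3c(OC)cc(OC)cc3n2S(=O)(=O)c2cc(F)c(F)c(F)c2)cc1` differs from compound 3 by 3,4,5-trifluorophenyl in place of 4-formylphenyl on a sulfonyl sulfur. The measured steps that touch the sulfonyl group, a step that the two limits leave unreadable from compound 1 to compound 3 and a step that the limit leaves unreadable from compound 2 to compound 3, carry no readable size, so they give no direction for the change on the aryl of that group. The step that the limit leaves unreadable from compound 3 to compound 4 is therefore expected to be nothing beyond the scatter. Compound 4 is estimated at 60000 nM in this assay, expected to fall between 25000 nM and 150000 nM, and most likely to be reported again as a limit.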

Compound 4, half-maximal effective concentration: > 65500 nM
Compound 4: only a limit was reported; the forecaster's own chance of this, stated with the estimate: 65%; at least 1.0-fold (0.03 log units) between middle value and limit.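

Compound 3 and compound 4 both give only limits in this assay, so the step to 3,4,5-trifluorophenyl in place of 4-formylphenyl on the sulfonyl sulfur has no readable size. The compounds shown leave open whether the aryl on that sulfonyl group affects the half-maximal effective concentration at all.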